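Methyl on the Aryl Ring of a Fused Sulfonamide Core

The compounds below may be only part of what the source reports. "The series", "measured", "known", "first", "only" and "open" are said of these compounds alone.

Measured compounds:
compound 1, `N#CC1=C(N)N(c2ccc(S(N)(=O)=O)cc2)C2=C(C(=O)CCC2)C1c1ccccc1`, in a functional assay on Ehrlich cells (Mus musculus) for antiproliferative activity, read by trypan blue exclusion, with a stated time of 2 h, tested at 100 ug/mL (on this read-out higher numbers stand for a stronger effect at the one concentration tested and lower numbers for a weaker effect), compound 1 gives 40%
compound 2, `Cc1ccc(C2C(C#N)=C(N)N(c3ccc(S(N)(=O)=O)cc3)C3=C2C(=O)CCC3)cc1`, in this assay compound 2 gives 100%
compound 3, `N#CC1=C(N)N(c2ccc(S(N)(=O)=O)cc2)C2=C(C(=O)CCC2)C1c1ccco1`, in this assay compound 3 gives 10%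

All three share the same core, a fused two-ring system carrying a nitrile, an amino group, a ketone and a 4-sulfamoylphenyl group on the ring nitrogen. They differ only in the aryl group on the saturated ring carbon.

Within the phenyl pair, the change methyl in place of hydrogen on an aromatic carbon raised the read-out, a number 60 percentage points higher from compound 1 to compound 2 (beyond the scatter). Swapping the aryl group itself lowered it: furan-2-yl in place of phenyl on a saturated ring carbon gives a number 30 percentage points lower from compound 1 to compound 3 (beyond the scatter), and going from the methylphenyl analogue gives a number 90 percentage points lower from compound 2 to compound 3 (beyond the scatter). Compound 3 thus stands lowest of the three.

Compound 4, `Cc1ccoc1C1C(C#N)=C(N)N(c2ccc(S(N)(=O)=O)cc2)C2=C1C(=O)CCC2`, is not yet measured. It relates to compound 3 as compound 2 relates to compound 1: methyl in place of hydrogen on an aromatic carbon. This is the same kind of change as in the phenyl pair, but not the same: there the methyl sits on a six-membered aromatic ring of carbon only, para to a large group; here on a five-membered aromatic ring with one oxygen, next to the ring atom that bears a large group and two ring bonds from the ring oxygen.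

The earlier step of a number 60 percentage points higher from compound 1 to compound 2 (beyond the scatter) suggests a rise for compound 4, but the different ring and place argue for caution, so a smaller step is expected, a number 25 percentage points higher from compound 3 to compound 4 (beyond the scatter). Compound 4 is therefore estimated at 35% in this assay, between 10% and 70%.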

Compound 4, a percentage reported as activity, at one concentration (the size of the read-out at that concentration, not a potency): 45%
Compound 4: the middle estimate sits 10 percentage points below what was measured; low and high end bracket the measured number.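

In this assay, the methyl raised the read-out on the furan-bearing compound as well, a number 35 percentage points higher from compound 3 to compound 4 (beyond the scatter), so the direction of the change carried over from one core to the other, while its size did not: the same change on two cores in this assay, a number 60 percentage points higher (beyond the scatter) from compound 1 to compound 2 and a number 35 percentage points higher (beyond the scatter) from compound 3 to compound 4, 25 percentage points apart, beyond the scatter of two such steps. Set against the other aryl groups, the 3-methylfuran-2-yl group gives a number 55 percentage points lower from compound 2 to compound 4 (beyond the scatter), and a number 5 percentage points higher from compound 1 to compound 4 (within the scatter), so the methylated furan cannot be told apart from the plain phenyl compound and does not reach the methylphenyl compound. These two pairs do not show whether the ring or the place of the methyl accounts for the gap between the steps, and they do not show how the change would behave on any further core.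

The compounds shown leave open whether an ethyl group, a methoxy group or a chlorine atom in place of this methyl would move the read-out in the same direction on both cores. They also show only a stronger or weaker effect at a single concentration, and two compounds can match there yet differ at other concentrations.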